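The source may hold more compounds than are shown below. What is called first, only, known or untested is meant among the compounds shown, and "the series" means these compounds.

Measured compounds:
Compound 1, `CCCCCCCCNc1n[n+]([O-])c2ccccc2[n+]1[O-]`, gives 4700 nM in a functional assay on K562 cells (Homo sapiens) for cytotoxicity, read by MTT assay, with a stated time of 48 h; a lower number here means a stronger inhibitor, a higher number a weaker inhibitor.
Compound 2, `C=CCNc1n[n+]([O-])c2ccccc2[n+]1[O-]`, gives 11200 nM in this assay.

Compound 2 holds the highest number of the two in this assay; its nearest neighbour, compound 1, lies a step away, and that step, a 2.4-fold higher number from compound 1 to compound 2 (0.38 log units; beyond the scatter), is modest yet beyond the scatter. The compound not yet measured is compound 3, `CCN(CC)c1n[n+]([O-])c2ccccc2[n+]1[O-]`. It differs from compound 2 by diethylamino in place of allylamino on an aromatic carbon. Going by the values given here, no measured step matches this change. Among the compounds with values here, the single step known, a 2.4-fold higher number from compound 1 to compound 2 (0.38 log units; beyond the scatter), concerns the length of the chain on the nitrogen rather than the exchange of an allylamino for a diethylamino group, so it offers only a loose guide. Compound 3 is therefore expected to sit near compound 2, with the estimated step of a 1.1-fold higher number from compound 2 to compound 3 (0.03 log units; within the scatter) falling within the scatter. Compound 3 is estimated at 12000 nM, with a range from 5000 nM to 30000 nM.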

Compound 3, half-maximal inhibitory concentration: > 55000 nM
Compound 3: no number, only a limit; the forecaster's own chance of this, stated with the estimate: 10%; middle value at least 4.5-fold (0.66 log units) from the limit.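

Going by these compounds alone, on the shared core, the earlier compounds showed only a change of chain on an amino nitrogen that keeps its hydrogen, whereas this change replaces allylamino with diethylamino and gives an at least 4.9-fold higher number from compound 2 to compound 3 (0.69 log units; beyond the scatter). In this assay compound 3 gives only a limit, > 55000 nM, and the full size of this step cannot be read: the limit of > 55000 nM in this assay, at which 1 of the 3 values shown sits.

The exchange replaces allylamino, with 1 hydrogen-bond donor and 1 double bond outside aromatic rings, with diethylamino, with 0 hydrogen-bond donors, and this single step does not separate these differences from one another.

The compounds shown leave open whether an ethylamino group would stay close to allylamino or fall with diethylamino. They also leave open how a dimethylamino group or a ring amine such as morpholine would behave at this position.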